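Trimethoxyphenyl in place of hydroxyphenyl: expected antiproliferative read-out

A few compounds are considered here, and "the series" means these few. Any claim that something is new, unique, unknown or untested is made for them only; others in the source may bear on it.

Measured compounds:
Compound 1 `COc1cc(N/C=C\C(=O)c2cn(-c3ccccc3)nc2-c2ccc(F)cc2)cc(OC)c1OC`: in an ADME assay on HaCaT cells (Homo sapiens) for antiproliferative activity, read by MTT assay, with a stated time of 48 h (on this read-out lower numbers stand for stronger inhibition and higher numbers for weaker inhibition), compound 1 gives 32800 nM.
Compound 2 `COc1ccc(-c2nn(-c3ccccc3)cc2C(=O)/C=C\Nc2ccc(O)cc2)cc1`: in this assay compound 2 gives 34600 nM.

Compound 2 has the higher of the two numbers, but its nearest neighbour, compound 1, sits within the scatter of it, so the two values show no difference worth calling one. Compound 3 `COc1ccc(-c2nn(-c3ccccc3)cc2C(=O)/C=C\Nc2cc(OC)c(OC)c(OC)c2)cc1` differs from compound 2 in one place: 3,4,5-trimethoxyphenyl in place of 4-hydroxyphenyl on an amine nitrogen. For the measured compounds named here, no pair of measured compounds differs in only one place, so no measured step guides this change directly; still, compound 1, which carries the same 3,4,5-trimethoxyphenyl on its amine nitrogen, gives a number close to that of compound 2. The step from compound 2 to compound 3 is therefore expected to be small, with no direction beyond the scatter, as a 1.1-fold lower number from compound 2 to compound 3 (0.05 log units; within the scatter). Compound 3 is estimated at 31000 nM, with a range from 12000 nM to 80000 nM.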

Compound 3, half-maximal inhibitory concentration: > 50000 nM
Compound 3: no number, only a limit (the forecaster's own chance of this, stated with the estimate: 10%); middle value at least 1.6-fold (0.20 log units) from the limit.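

Compound 3 can be read only against a limit of the assay: the limit of > 50000 nM in this assay, at which 1 of the 3 values shown sits.

For the compounds shown here, it nevertheless gives the first comparisons in one place, and at the amine nitrogen 3,4,5-trimethoxyphenyl in place of 4-hydroxyphenyl gives an at least 1.4-fold higher number from compound 2 to compound 3 (0.15 log units; that floor lies within the scatter), while methoxy in place of fluoro on an aromatic carbon gives an at least 1.5-fold higher number from compound 1 to compound 3 (0.18 log units; that floor lies within the scatter). Neither change yields a lower number in this assay, although both floors lie within the scatter, so neither step is established as a real loss of inhibition.

From the compounds shown here alone, how large either step is remains open, as does whether either one exceeds the scatter. Also open, going by these compounds, is how a phenyl carrying an amine or a carboxylic acid would read on the same amine nitrogen.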